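Ortho-hydroxybenzanilides and a benzothiazolylthio anilide in chaperonin inhibition

The source may report more compounds than this note shows. Statements on the series, on what has been measured and on what is new or still open speak of the compounds shown alone.

Measured compounds:
compound 1 `O=C(Nc1cccc(Cl)c1)c1cc(Br)cc(Br)c1O`, 29000 nM
compound 2 `COc1ccc(Br)cc1C(=O)Nc1ccc(Sc2nc3ccccc3s2)cc1`, > 100000 nM
compound 3 `O=C(Nc1ccccc1)c1cc(Br)cc(Br)c1O`, 63000 nM

In an assay for inhibition of HSP60/HSP10 (Homo sapiens), with a stated time of 60 min (a higher number here means a weaker inhibitor, a lower number a stronger inhibitor), compound 1 gives 29000 nM. Among the measured compounds shown here, compound 3 gives 63000 nM in this assay, and the one measured single-point step, a 2.2-fold higher number from compound 1 to compound 3 (0.34 log units; beyond the scatter), concerns hydrogen in place of chloro on an aromatic carbon of the anilide ring. For compound 2 this assay reports only a limit, > 100000 nM; this value sits at the limit of > 100000 nM in this assay, at which 1 of the 3 values shown sits, so compound 2 stands at the weak end of what is shown, with no number of its own.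

The unmeasured compound 4 `O=C(Nc1ccc(Sc2nc3ccccc3s2)cc1)c1ccccc1O` differs from compound 2 by 2-hydroxyphenyl in place of 5-bromo-2-methoxyphenyl on a carbonyl carbon. Neither measured step touches this part of the molecule: the step from compound 1 to compound 3 alters the anilide ring, not the acyl ring, so it gives no direct guide to the size of the change here. What the data do show is that the two compounds carrying a hydroxy group on the acyl ring, compound 1 and compound 3, return measurable numbers, while compound 2, with the methoxy-bromo acyl ring, returns only a limit. Compound 4 is therefore expected to give a measurable value, estimated at 60000 nM (range 20000 nM to 200000 nM), which would be the expected step of an at least 1.6-fold lower number from compound 2 to compound 4 (0.22 log units; that floor lies within the scatter), though the chance that this assay again reports only a limit remains considerable.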

Compound 4, half-maximal inhibitory concentration: > 100000 nM
Compound 4 was reported as a limit (the forecaster's own chance of this, stated with the estimate: 40%); middle value at least 1.6-fold (0.22 log units) away from the limit.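

In this assay, compound 2 and compound 4 are both reported only as limits, so no step can be read between them: the limit of > 100000 nM in this assay, at which 2 of the 4 values shown sit. The compounds shown leave open whether 2-hydroxyphenyl in place of 5-bromo-2-methoxyphenyl on a carbonyl carbon changes inhibition at all, and in which direction.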